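Butyl for methoxyphenyl on the shared core

The source may hold more compounds than are shown below. What is called first, only, known or untested is meant among the compounds shown, and "the series" means these compounds.

Within the data shown here, compound 1 `COc1ccc(-c2cn(C[C@H](O)[C@H]3OC(=O)C(OCc4ccccc4)=C3OCc3ccccc3)nn2)cc1` is the only compound with a number in a functional assay on HepG2 cells (Homo sapiens) for antiproliferative activity, read by MTT assay, with a stated time of 72 h; a higher number here means a weaker inhibitor, a lower number a stronger inhibitor: compound 1 gives 46400 nM. Compound 2 `O=C1O/C(=C\Cn2cc(-c3cc(C(F)(F)F)cc(C(F)(F)F)c3)nn2)C(OCc2ccccc2)=C1OCc1ccccc1` reaches only a limit in this assay, where compound 2 gives > 100000 nM; this is a limit of the assay and not a number. Compound 1 therefore stands as the lowest number shown, the other value sitting at the limit (the limit of > 100000 nM in this assay, at which 1 of the 2 values shown sits).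

Compound 3 `CCCCc1cn(C[C@H](O)[C@H]2OC(=O)C(OCc3ccccc3)=C2OCc2ccccc2)nn1` is not yet measured in this assay. It differs from compound 1 in one place (butyl in place of 4-methoxyphenyl on an aromatic carbon). Among the measured compounds shown here, no step between two measured compounds covers a change of this kind, so the size of the step is open. The estimate is a step from compound 1 to compound 3 of a 1.3-fold higher number from compound 1 to compound 3 (0.11 log units; within the scatter) in this assay, within the usual scatter. Compound 3 is thus expected to give 60000 nM in this assay, between 20000 nM and 150000 nM, and a result reported only as a limit is not excluded.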

Compound 3, half-maximal inhibitory concentration: 32800 nM
The estimate for compound 3 lay 1.8-fold (0.26 log units) above the measured number; the range from low to high includes it.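

In this assay the change reads as a 1.4-fold lower number from compound 1 to compound 3 (0.15 log units; within the scatter) and so gives no order between the two compounds. At this position on the five-membered aromatic ring with 3 nitrogen, an open butyl chain thus stands in for 4-methoxyphenyl, with its six-membered aromatic ring and hydrogen-bond acceptor, without a change beyond the scatter, and the aromatic ring is not needed to hold the read-out at this level. Nothing on hand bears on why this step is so small, and no cause can be given for it.

Open, on these data alone, is whether a longer chain, such as octyl, or a shorter one, such as methyl, at this position would move the number beyond the scatter. Also open, as far as these compounds go, is how an amine or a carboxylic acid at the end of the butyl chain would read in this assay on the same core.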